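The source may hold more compounds than are shown below. What is called first, only, known or untested is meant among the compounds shown, and "the series" means these compounds.

Three esters of a shared core carry a triazole whose aromatic nitrogen bears a different aryl group. Compound 1 `C/C(=C\CC/C(C)=C/CC[C@@H]1[C@@]2(C)CCC(=O)C(C)(C)[C@H]2CC[C@@]1(C)O)CC/C=C(\C)C(=O)OCc1cn(-c2ccc(F)cc2)nn1` carries 4-fluorophenyl, compound 2 `C/C(=C\CC/C(C)=C/CC[C@@H]1[C@@]2(C)CCC(=O)C(C)(C)[C@H]2CC[C@@]1(C)O)CC/C=C(\C)C(=O)OCc1cn(-c2ccccc2C(F)(F)F)nn1` carries 2-(trifluoromethyl)phenyl, and compound 3 `C/C(=C\CC/C(C)=C/CC[C@@H]1[C@@]2(C)CCC(=O)C(C)(C)[C@H]2CC[C@@]1(C)O)CC/C=C(\C)C(=O)OCc1cn(-c2ccccc2C)nn1` carries 2-methylphenyl. In a functional assay on DU-145 cells (Homo sapiens) for antiproliferative activity, read by MTT assay, with a stated time of 48 h (a lower number here means a stronger inhibitor, a higher number a weaker inhibitor), compound 1 gives only a limit of the assay, > 150000 nM. In this assay compound 2 likewise gives only a limit, > 150000 nM. In this assay compound 3 also gives only a limit, > 150000 nM. Compound 2 therefore stands nowhere in particular on the numbers shown: it sits at the limit together with the two other compounds, as the limit of > 150000 nM in this assay, at which 3 of the 3 values shown sit, records, and the steps a step that the two limits leave unreadable from compound 1 to compound 2, a step that the two limits leave unreadable from compound 1 to compound 3 and a step that the two limits leave unreadable from compound 2 to compound 3 cannot be read in size or direction.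

Compound 4 `C/C(=C\CC/C(C)=C/CC[C@@H]1[C@@]2(C)CCC(=O)C(C)(C)[C@H]2CC[C@@]1(C)O)CC/C=C(\C)C(=O)OCc1cn(-c2cccc(Cl)c2)nn1` is not yet measured. It differs from compound 2 in one place: 3-chlorophenyl in place of 2-(trifluoromethyl)phenyl on an aromatic nitrogen. All three measured steps bear on this change only in that they exchange one aryl group on the same aromatic nitrogen for another, and none of them moved a compound off the limit. No step beyond the scatter is therefore expected in this assay, in either direction, and the step that the limit leaves unreadable from compound 2 to compound 4 is estimated to be unreadable as well. Compound 4 is expected to give 200000 nM, within a range from 60000 nM to 600000 nM.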

Compound 4, half-maximal inhibitory concentration: 103000 nM
For compound 4 the middle estimate is 1.9-fold (0.29 log units) above the measured one, and the stated range covers the measured number.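

In this assay, compound 4, with 3-chlorophenyl on the aromatic nitrogen, gives a number, whereas every other compound shown stops at a limit of the assay: the limit of > 150000 nM in this assay, at which 3 of the 4 values shown sit. Among these compounds, this shows that exchanging one aryl group for another at this nitrogen, with the rest of the shared core unchanged, can bring a compound within the readable range of the assay, which the earlier compounds could not show. The steps are an at least 1.4-fold lower number from compound 2 to compound 4 (0.16 log units; that floor lies within the scatter), an at least 1.4-fold lower number from compound 3 to compound 4 (0.16 log units; that floor lies within the scatter) and an at least 1.4-fold lower number from compound 1 to compound 4 (0.16 log units; that floor lies within the scatter); each is only a floor, so the data fix neither how large the true gaps are nor whether they exceed the scatter.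

The compounds shown leave open whether the readable number of compound 4 goes with the chlorine itself or with its place on the phenyl ring, as a single 3-chlorophenyl compound cannot separate the two. They also leave open how this nitrogen would respond to a group other than a substituted phenyl, such as a benzyl group, a longer chain ending in an amine, or a phenyl ring bearing a carboxylic acid.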